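The source may hold more compounds than are shown below. What is called first, only, known or untested is meant among the compounds shown, and "the series" means these compounds.

Compound 1 `N=c1oc2ccccc2cc1C(=O)N/N=C1\C(=O)Nc2ccc(S(=O)(=O)N3CCOCC3)cc21`: 20800 nM
Compound 2 `CC(=O)N/N=C1\C(=O)Nc2ccc(S(=O)(=O)N3CCOCC3)cc21`: 56000 nM

In a functional assay on MCF7 cells (Homo sapiens) for cytotoxicity, read by sulforhodamine B assay, with a stated time of 24 h (a higher number here means a weaker inhibitor, a lower number a stronger inhibitor), compound 2 gives 56000 nM, the higher of the two numbers, which makes it the weaker inhibitor of this pair. Compound 3 `O=C1Nc2ccc(S(=O)(=O)N3CCOCC3)cc2/C1=N/c1ccc(Cl)cc1` keeps the shared core and carries 4-chlorophenyl in place of acetamido on a double-bonded nitrogen. For the measured compounds named here, only one measured step offers a guide, a 2.7-fold higher number from compound 1 to compound 2 (0.43 log units; beyond the scatter). There, a group with aromatic rings gave way to a single carbon and the number rose modestly. That change sat on a carbonyl carbon, not on a double-bonded nitrogen, so it is a weak hint. Compound 3 gains an aromatic ring, so a modest move towards a lower number is expected in this assay. The expected step is a 2.2-fold lower number from compound 2 to compound 3 (0.33 log units; beyond the scatter). For compound 3 the estimated value is 26000 nM, with an expected range from 8000 nM to 80000 nM.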

Compound 3, half-maximal inhibitory concentration: 44300 nM
Estimate against measurement, compound 3: 1.7-fold (0.23 log units) below, within the range that was stated.
By their numbers in this assay, from the lowest: compound 1; then compounds 3 and 2 (each within the scatter of the next).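

In this assay, putting 4-chlorophenyl in place of acetamido on a double-bonded nitrogen gives a 1.3-fold lower number from compound 2 to compound 3 (0.10 log units; within the scatter) and so leaves the two compounds within the scatter of each other. For the compounds shown here, this is the first direct reading of a change at this position, and it shows that this exchange does not separate the compounds in this assay. The two groups differ in their ring, in their size and in their hydrogen-bond donor and acceptor counts, yet those differences come with no clear shift in the number here, and no supporting measurement offers an explanation.

As far as these compounds go, whether a plain phenyl would read the same as 4-chlorophenyl remains open. So does whether an amine or a longer chain ending in a carboxylic acid on this nitrogen would move the number beyond the scatter.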